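From a sulfur ring to a chloropyridine

The source may report more compounds than this note shows. Statements on the series, on what has been measured and on what is new or still open speak of the compounds shown alone.

Values measured so far in a functional assay on Shh Light II cells (Mus musculus) for inhibition, read by a luciferase reporter (a higher number here means a weaker inhibitor, a lower number a stronger inhibitor), are these:
compound 1 `O=C(Nc1ccccc1Cl)N1CCC(c2nc(-c3ccc4ccccc4n3)no2)CC1` gives 510 nM
compound 2 `Cn1c(-c2noc(C3CCN(C(=O)NC4CCCCC4)CC3)n2)nc2ccccc21` gives 89 nM
compound 3 `O=C(NC1CC[S+]([O-])CC1)N1CCC(c2nc(-c3ccc4ccccc4n3)no2)CC1` gives 850 nM

Compound 3 lies within the scatter of compound 1, so those two cannot be separated, while compound 2 shows a clearly lower number, meaning a stronger inhibitor. Compound 4 `O=C(Nc1ncccc1Cl)N1CCC(c2nc(-c3ccc4ccccc4n3)no2)CC1` is not yet measured. It differs from compound 3 on an amide-type nitrogen, where 3-chloropyridin-2-yl enters (a group of 7 heavy atoms (5 carbon, 1 nitrogen, 1 chlorine; one six-membered aromatic ring with 1 hetero atom) in place of a group of 7 heavy atoms (5 carbon, 1 oxygen, 1 sulfur; one six-membered non-aromatic ring with 1 hetero atom), on an amide-type nitrogen). Within the data shown here, the one measured step at this nitrogen is a 1.7-fold higher number from compound 1 to compound 3 (0.22 log units; within the scatter) and it links a chlorine-bearing aromatic ring to the same sulfur ring that leaves here. On that evidence, no change beyond the scatter is expected in this assay for this swap. The estimated change is a 1.5-fold lower number from compound 3 to compound 4 (0.19 log units; within the scatter) and remains only an expectation. Compound 4 is expected at 550 nM with an estimated range from 200 nM to 1500 nM until it is measured.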

Compound 4, half-maximal inhibitory concentration: 2800 nM
Beside the measured number, compound 4's estimate is 5.1-fold (0.71 log units) below it; the measured number lies above the stated range.
By their numbers in this assay, from the lowest: compound 2; then compounds 1 and 3 (each within the scatter of the next); then compound 4.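

At this amide-type nitrogen, putting 3-chloropyridin-2-yl in place of 2-chlorophenyl gives a 5.5-fold higher number from compound 1 to compound 4 (0.74 log units; beyond the scatter) in this assay, so a single ring nitrogen separates two otherwise identical compounds. The same group also gives a 3.3-fold higher number from compound 3 to compound 4 (0.52 log units; beyond the scatter) against the sulfur ring, so this position is less tolerant than the earlier pair, compound 1 and compound 3, suggested. Nothing measured here explains either step.

Still open, going by these compounds, is how a plain phenyl or a methoxyphenyl would fare on this nitrogen. Also open, on these data alone, is whether 3-chloropyridin-2-yl would bring a similar change on the core of compound 2.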